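A few compounds are considered here, and "the series" means these few. Any claim that something is new, unique, unknown or untested is made for them only; others in the source may bear on it.

In a physicochemical assay for lipophilicity, using the shake flask method, in phosphate buffer, measured as octanol-water partition, with a stated time of 30 min, at pH 7.4 (a higher number here means a more lipophilic compound, a lower number a more polar compound), compound 1 (`O=C1c2ccccc2CN1c1cnc(NCc2c(F)ccc3c2CCO3)n2cnnc12`) stands at 2.7 as the higher of two numbers, and compound 2 (`COCCC(=O)Nc1cnc(NCc2c(F)ccc3c2CCO3)n2cnnc12`) gives 1.4 against it. Compound 3 (`CN(C)Cc1ccc2c(c1)CN(c1cnc(NCc3c(F)ccc4c3CCO4)n3cnnc13)C2=O`) differs from compound 1 by a single change ((dimethylamino)methyl in place of hydrogen on an aromatic carbon), with (dimethylamino)methyl in place of hydrogen on an aromatic carbon. Among the compounds with values here, the only measured step is a number 1.30 log units lower from compound 1 to compound 2 (beyond the scatter) and it bears on this change only loosely: there a whole group is replaced, whereas here one is added. A smaller fall, still beyond the scatter, is therefore expected (a number 0.80 log units lower from compound 1 to compound 3 (beyond the scatter)). Compound 3 is expected at 1.9 (estimated range 1.3 to 2.5).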

Compound 3, distribution coefficient: 1.6
Estimate against measurement, compound 3: 0.30 log units above; the range from low to high includes it.
By their numbers in this assay, from the lowest: compounds 2 and 3 (each within the scatter of the next); then compound 1.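

In this assay, (dimethylamino)methyl in place of hydrogen on an aromatic carbon gives a number 1.10 log units lower from compound 1 to compound 3 (beyond the scatter). The group of compound 1 therefore need not be replaced as a whole: one added substituent on this aromatic carbon is enough for a large step. No available measurement accounts for the size of this step.

Open, going by these compounds, is whether a carboxylic acid, a hydroxymethyl or a longer chain ending in an amine on this same carbon would give a step of similar size. Also open, on these data alone, is how (dimethylamino)methyl would behave on another carbon of this ring.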